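From (piperidin-1-yl)methyl to 4-hydroxypiperidin-1-yl on the shared core

The source may hold more compounds than are shown below. What is called first, only, known or untested is meant among the compounds shown, and "the series" means these compounds.

Of the compounds shown here, three built on the shared core have been tested in an ADME assay on L6 cells (Rattus norvegicus) for cytotoxicity; a lower number here means a stronger inhibitor, a higher number a weaker inhibitor. Compound 1 `CCN(CC)CC(=O)OC1CC2(N3CCCCC3)CC(c3ccccc3)C1C(c1ccccc1)C2` gave 23900 nM; 61300 nM (2 entries), and compound 2 `O=C(CN1CCCC1)OC1CC2(N3CCCCC3)CC(c3ccccc3)C1C(c1ccccc1)C2` gave 16400 nM; 52000 nM (2 entries), so each has two entries that lie well apart. Compound 3 `O=C(CCN1CCCCC1)OC1CC2(N3CCCCC3)CC(c3ccccc3)C1C(c1ccccc1)C2` has a single entry of 54600 nM, a number that falls within the span of the two entries of compound 1.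

Compound 4 `O=C(CN1CCC(O)CC1)OC1CC2(N3CCCCC3)CC(c3ccccc3)C1C(c1ccccc1)C2` differs from compound 3 in one place: on a saturated chain carbon bound to a carbonyl carbon, 4-hydroxypiperidin-1-yl stands in place of (piperidin-1-yl)methyl (4-hydroxypiperidin-1-yl in place of (piperidin-1-yl)methyl on a saturated chain carbon bound to a carbonyl carbon). For the measured compounds named here, no measured pair of compounds isolates a change in one place, so the expectation rests on the level of the series, with compound 3 as the closest anchor at 54600 nM. In this assay, no shift beyond the scatter is expected. The expected change is small, a 1.1-fold lower number from compound 3 to compound 4 (0.04 log units; within the scatter). For compound 4 the estimated value is 50000 nM, with an expected range of 20000 nM to 110000 nM.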

Compound 4, half-maximal inhibitory concentration: > 179000 nM
Compound 4 gave a limit, no number (the forecaster's own chance of this, stated with the estimate: 15%); at least 3.5-fold (0.55 log units) between middle value and limit.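

The result gives the series its first step in one place, on a saturated chain carbon bound to a carbonyl carbon, where 4-hydroxypiperidin-1-yl stands in place of (piperidin-1-yl)methyl: an at least 3.2-fold higher number from compound 3 to compound 4 (0.51 log units; beyond the scatter). In this assay compound 4 gives > 179000 nM, which is a limit of the assay and not a number. This shows that a change at this position can move the read-out beyond the scatter, though the step has only a lower bound and its full size stays unknown: the limit of > 179000 nM in this assay, at which 1 of the 4 values shown sits.

On these data alone, the same difference also reads as 2-(piperidin-1-yl)ethyl to (4-hydroxypiperidin-1-yl)methyl, so how the step divides between the hydroxy group and the chain remains open. Also open, as far as these compounds go, is where a 4-methoxypiperidin-1-yl or a 4-aminopiperidin-1-yl group would fall in this assay.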